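Two-fluorine phenyl replaces trifluoromethylphenyl on the ring nitrogen

This account rests on a few compounds, and the source may have more. Where it says the series, first, only, none or still open, it means among the compounds named here.

Compound 1 `Nc1scc(CN2CCN(c3cccc(C(F)(F)F)c3)CC2)c1C(=O)c1ccc(Cl)cc1`: -30%
Compound 2 `Nc1scc(CN2CCN(c3ccccc3C(F)(F)F)CC2)c1C(=O)c1ccc(Cl)cc1`: -7.5%
Compound 3 `Nc1scc(CN2CCN(c3ccc(C(F)(F)F)cc3)CC2)c1C(=O)c1cccc(C(F)(F)F)c1`: -11%

In a functional assay on CHO cells with adenosine receptor A1 (Homo sapiens) as the target, read by cAMP accumulation and immunoassay, with a stated time of 6 min, tested at 0.1 uM (on this read-out higher numbers stand for a weaker effect at the one concentration tested and lower numbers for a stronger effect), compound 1 gives -30%, compound 2 gives -7.5% and compound 3 gives -11%. Compound 3 thus stands second highest of the three numbers, within the scatter of compound 2 and a number clearly lower than compound 1. For the measured compounds named here, the only single-place step among the measured compounds is a number 22.5 percentage points higher from compound 1 to compound 2 (beyond the scatter).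

Compound 4 `Nc1scc(CN2CCN(c3c(F)cccc3F)CC2)c1C(=O)c1cccc(C(F)(F)F)c1` differs from compound 3 by 2,6-difluorophenyl in place of 4-(trifluoromethyl)phenyl on an amine nitrogen in a ring. Going by the values given here, no measured step covers this exact exchange; the step from compound 1 to compound 2 is the only one that alters the phenyl on the ring nitrogen, and it was modest. Exchanging that phenyl again is therefore expected to move the number little, possibly upward, and the step from compound 3 to compound 4 is estimated at a number 6 percentage points higher from compound 3 to compound 4 (within the scatter). Compound 4 is accordingly expected to give -5% in this assay, with a range from -25% to 15%.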

Compound 4, a percentage reported as activity, at one concentration (the size of the read-out at that concentration, not a potency): 1.3%
For compound 4 the middle estimate is 6.3 percentage points below the measured one; low and high end bracket the measured number.
By their numbers in this assay, from the lowest: compound 1; then compounds 3, 2 and 4 (each within the scatter of the next, the first and the last beyond it).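

In this assay, exchanging 4-(trifluoromethyl)phenyl for 2,6-difluorophenyl on an amine nitrogen in a ring gives a number 12.3 percentage points higher from compound 3 to compound 4 (beyond the scatter) and so shows that the number at this position responds to replacing the trifluoromethyl group with fluorine, not only to moving that group around the phenyl, as in a number 22.5 percentage points higher from compound 1 to compound 2 (beyond the scatter). Both steps at this nitrogen run toward a higher number, and neither of the listed exchanges goes against that direction. Nothing available explains the step from compound 3 to compound 4. The compounds shown leave open how a plain phenyl, a phenyl with a single fluorine or a pyridine on that nitrogen would read in this assay. They also leave open whether the same exchange would give a comparable step from compound 1 or compound 2.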